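Swapping One Ring Group on a Shared Core at A3

The compounds below may be only part of what the source reports. "The series", "measured", "known", "first", "only" and "open" are said of these compounds alone.

Three compounds built on one shared core were tested in an assay on CHO cells for displacement of a labelled ligand from adenosine receptor A3 (Homo sapiens), read by scintillation counting, tested at 10 uM; on this read-out higher numbers stand for more inhibition at the one concentration tested (going by the name of the read-out) and lower numbers for less inhibition. Compound 1 `CC(C)Cc1csc(N)c1C(=O)c1ccc(Cl)cc1` gives 1%, compound 2 `Nc1sc(-c2ccccc2)c(-c2ccccc2)c1C(=O)c1ccc(Cl)cc1` gives 1%, and compound 3 `CC(C)(C)Cc1c(-c2ccccn2)sc(N)c1C(=O)c1ccc(Cl)cc1` gives 1%. Compound 3 therefore stands level with compounds 1 and 2 at the digits shown, within the usual scatter of each. Compound 4 `CC(C)(C)Cc1c(/C=C/c2ccc(Cl)cc2)sc(N)c1C(=O)c1ccc(Cl)cc1` differs from compound 3 in a single place: 2-(4-chlorophenyl)ethenyl in place of pyridin-2-yl on an aromatic carbon. Within the data shown here, no step between measured compounds has been recorded, so nothing shows how a change at this position moves the read-out. Because compound 3 sits at 1% and its two companions show the same, compound 4 is expected to stay close by, with a step of a number 4 percentage points higher from compound 3 to compound 4 (within the scatter) in this assay. Compound 4 is estimated at 5%, between 0% and 30%.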

Compound 4, a percentage reported as inhibition, at one concentration (the size of the read-out at that concentration, not a potency): 11%
Compound 4: middle estimate off by 6 percentage points, on the low side; measured number inside the range.
By their numbers in this assay, from the lowest: compounds 1, 2, 3 and 4 (each within the scatter of the next).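

Putting 2-(4-chlorophenyl)ethenyl in place of pyridin-2-yl, on the ring carbon next to the ring sulfur, gives a number 10 percentage points higher from compound 3 to compound 4 (within the scatter) in this assay. Among these compounds, this is the first change seen at this position, and at this single concentration the read-out does not separate the two groups. Nothing measured here bears on what lies behind this step.

From the compounds shown here alone, whether an amine or a carboxylic acid at this position would move the read-out beyond the scatter remains open. So does whether a group other than neopentyl on the neighbouring ring atom would do so.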